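Sulfonamide for amide on the amine nitrogen: stability outlook

The source may report more compounds than this note shows. Statements on the series, on what has been measured and on what is new or still open speak of the compounds shown alone.

Compound 3 `CCCCCC(=O)N[C@@H]1CCN(c2cc(C)nn3c(-c4ccc(OC)c(OC)c4)c(C)nc23)C1` in an ADME assay on microsomes from liver (Mus musculus) for metabolic stability, read by LC-MS, with NADPH named in the record, with a stated time of 60 min, tested at 1 uM, in the absence of a further agent (a lower number here means that less of the compound is left, a higher number that more of the compound is left), reaches only the limit, > 95%. Compound 1 `COc1cc(-c2c(C)nc3c(N4CC[C@@H](NC(C)=O)C4)cc(C)nn23)ccc1F` likewise stands at the limit, > 95%. Compound 2 `COc1ccc(-c2c(C)nc3c(N4CC[C@@H](NC(C)=O)C4)cc(C)nn23)cn1` also stands at the limit, > 95%. Among the measured compounds shown here, the single measured step, a step that the two limits leave unreadable from compound 1 to compound 2, is unreadable, and the limit of > 95% in this assay, at which 3 of the 3 values shown sit, leaves no readable spread within the set. Compound 4 `COc1ccc(-c2c(C)nc3c(N4CC[C@@H](NS(=O)(=O)c5cccs5)C4)cc(C)nn23)cc1OC` differs from compound 3 by (thiophen-2-yl)sulfonyl in place of pentylcarbonyl on an amine nitrogen. For the measured compounds named here, no measured step touches the group on the amine nitrogen; the values in hand give no direction for this change beyond all three sitting at the limit. For compound 4 the expected result in this assay is 90%, within 65% to 99%. The expected step, a number at least 5 percentage points lower from compound 3 to compound 4 (that floor lies within the scatter), is estimated to stay within the scatter.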

Compound 4, percent of the compound remaining: > 95%
Compound 4: a limit, no number (the forecaster's own chance of this, stated with the estimate: 55%); middle value at least 5 percentage points from the limit.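

Compound 4, like compound 3, gives only a limit, so no step between them can be read: the limit of > 95% in this assay, at which 4 of the 4 values shown sit.

The compounds shown leave open whether pentylcarbonyl and (thiophen-2-yl)sulfonyl on an amine nitrogen differ at all in the percent of compound remaining.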